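Aryl thioether variation on a nucleoside scaffold for transporter binding

The source may hold more compounds than are shown below. What is called first, only, known or untested is meant among the compounds shown, and "the series" means these compounds.

Measured compounds in an assay on isolated protein for binding affinity to Equilibrative nucleoside transporter 1 (Homo sapiens); on this read-out higher numbers stand for weaker inhibition and lower numbers for stronger inhibition:
Compound 1, `Cc1cc(C)c(SCc2ncnc3c2ncn3[C@@H]2O[C@H](CO)[C@@H](O)[C@H]2O)c(C)c1`, gives 33100 nM.
Compound 2, `OC[C@H]1O[C@@H](n2cnc3c(CSc4ccccc4I)ncnc32)[C@H](O)[C@@H]1O`, gives 282 nM.
Compound 3, `OC[C@H]1O[C@@H](n2cnc3c(CSc4ccc(Cl)c(Cl)c4)ncnc32)[C@H](O)[C@@H]1O`, gives 224 nM.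

Compound 3 shows the lowest number of the three, but its nearest neighbour, compound 2, lies within the scatter of it (a 1.3-fold lower number from compound 2 to compound 3 (0.10 log units; within the scatter)), so the two cannot be ranked against each other. Both stand far from compound 1: the steps of a 120-fold lower number from compound 1 to compound 2 (2.07 log units; beyond the scatter) and a 150-fold lower number from compound 1 to compound 3 (2.17 log units; beyond the scatter) are large and well beyond the scatter.

Compound 4, `COC(=O)c1ccc(SCc2ncnc3c2ncn3[C@@H]2O[C@H](CO)[C@@H](O)[C@H]2O)cc1`, has not yet been measured in this assay. It differs from compound 3 in one place: 4-(methoxycarbonyl)phenyl in place of 3,4-dichlorophenyl on a sulfur. Within the data shown here, no measured step involves a 4-(methoxycarbonyl)phenyl group, so nothing directly shows how this change acts. The measured steps do show that the aryl group on the sulfur can shift the number by a large amount in either direction; compound 1 marks the weak end, compounds 2 and 3 the strong end. A moderate rise in the number relative to compound 3 is therefore expected, a 3.6-fold higher number from compound 3 to compound 4 (0.55 log units; beyond the scatter), with wide uncertainty. The estimate for compound 4 is 800 nM, with a range from 150 nM to 5000 nM.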

Compound 4, half-maximal inhibitory concentration: 813 nM
For compound 4 the middle estimate is 1.0-fold (0.01 log units) below the measured one, and the stated range covers the measured number.
By their numbers in this assay, from the lowest: compounds 3 and 2 (each within the scatter of the next); then compound 4; then compound 1.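

In this assay, the 4-(methoxycarbonyl)phenyl group, which unlike 3,4-dichlorophenyl carries hydrogen-bond acceptors, gives an intermediate result on the sulfur: a 3.6-fold higher number from compound 3 to compound 4 (0.56 log units; beyond the scatter) and a 2.9-fold higher number from compound 2 to compound 4 (0.46 log units; beyond the scatter) are both modest, while a 41-fold lower number from compound 1 to compound 4 (1.61 log units; beyond the scatter) is large. The set therefore no longer splits into only a weak and a strong end, since compound 4 lies between them. Its printed value stands much closer to those of compound 2 and compound 3 than to that of compound 1, so an aryl group bearing a methyl ester on this sulfur keeps most of the gain over 2,4,6-trimethylphenyl.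

As far as these compounds go, whether a carboxylic acid or an amide in place of the methyl ester would stay near compound 4 remains open. The cause of these steps is open too, as no measurement here addresses it.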